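Removing the aroyl group from the ring nitrogen

This account rests on a few compounds, and the source may have more. Where it says the series, first, only, none or still open, it means among the compounds named here.

Three compounds of this series have numbers in a functional assay on NUGC-3 cells (Homo sapiens) for cytotoxicity, read by sulforhodamine B assay, with a stated time of 72 h; on this read-out higher numbers stand for weaker inhibition of growth and lower numbers for stronger inhibition of growth. Compound 1 `O=C(Nc1cc(C(F)(F)F)cc(C(F)(F)F)c1)C1CCc2ccccc2N1C(=O)c1cccc(Cl)c1` gives 560 nM and stands lowest of the three; both other numbers lie beyond the scatter from it. Compound 2 `O=C(Nc1ccccc1C(F)(F)F)C1CCc2ccccc2N1`, which carries hydrogen on the ring nitrogen and differs elsewhere as well, gives 39300 nM. Compound 3 `CCCCCCCCC(=O)N1c2ccccc2CCC1C(=O)Nc1ccccc1O`, which carries a nonanoyl group on the ring nitrogen and also differs elsewhere, gives 31100 nM. No pair among these differs in one place only, so the weak numbers of compound 2 and compound 3 cannot be assigned to a single change.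

Compound 4 `O=C(Nc1cc(C(F)(F)F)cc(C(F)(F)F)c1)C1CCc2ccccc2N1` has not been measured in this assay. It differs from compound 1 as follows: hydrogen in place of (3-chlorophenyl)carbonyl on a nitrogen on an aromatic ring in a ring. Within the data shown here, compound 2 is the only measured compound with hydrogen on the ring nitrogen, and its number of 39300 nM is far above that of compound 1, though other parts of the molecule differ too. On that basis a large loss is expected, a 27-fold higher number from compound 1 to compound 4 (1.43 log units; beyond the scatter), well beyond the scatter, though the size is uncertain. Compound 4 is therefore estimated at 15000 nM, with a range from 3000 nM to 60000 nM.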

Compound 4, concentration for 50% growth inhibition: 8760 nM
The estimate for compound 4 lay 1.7-fold (0.23 log units) above the measured number; measured number inside the range.
By their numbers in this assay, from the lowest: compound 1; then compound 4; then compounds 3 and 2 (each within the scatter of the next).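

In this assay, among these compounds, the step of a 16-fold higher number from compound 1 to compound 4 (1.19 log units; beyond the scatter) gives the first reading of the ring nitrogen with the rest of the molecule held constant, which the earlier compounds could not provide. The (3-chlorophenyl)carbonyl group therefore goes with much of the growth inhibition seen for compound 1 on this scaffold, and its replacement by hydrogen alone is enough for a large loss. The change removes the carbon-only aromatic ring, the carbonyl and the chlorine together, so the step belongs to the group as a whole, and nothing on hand explains its size.

On these data alone, it remains open which part of the group carries the step: a plain benzoyl group would separate the chlorine from the rest, and an acetyl group would separate the carbonyl from the aromatic ring. As far as these compounds go, it is also open whether a sulfonyl link or a benzyl group on the ring nitrogen would hold the number of compound 1, and whether the step keeps its size when the aryl group on the other side of the core changes.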